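The compounds below may be only part of what the source reports. "The series", "measured", "known", "first", "only" and "open" are said of these compounds alone.

Measured to date in a functional assay on PANC-1 cells (Homo sapiens) for inhibition, read by MTT assay, with a stated time of 24 h, tested at 10 uM; on this read-out lower numbers stand for less inhibition and higher numbers for more inhibition at the one concentration tested (going by the name of the read-out):
compound 1 `CC(C)=CCC/C(C)=C/CC1Cc2c(O)cc(=O)n(CCCO)c2CC1(C)C` gives 28.7%
compound 2 `CC(C)=CCC/C(C)=C/CC1Cc2c(OCCCNS(=O)(=O)c3ccc([N+](=O)[O-])cc3)cc(=O)n(CCCO)c2CC1(C)C` gives 7.4%

Compound 2 stands lowest of the two numbers; the nearest, compound 1, lies higher by a gap beyond the usual scatter. Compound 3 `CC(C)=CCC/C(C)=C/CC1Cc2c(OCCCNC(=O)c3ccco3)cc(=O)n(CCCO)c2CC1(C)C` is not yet measured. It differs from compound 2 by (furan-2-yl)carbonyl in place of (4-nitrophenyl)sulfonyl on an amine nitrogen. Going by the values given here, no pair of measured compounds isolates this change, so the expected step in this assay is small, upward if anything, and most likely within the scatter. For compound 3 the expected step is a number 6.6 percentage points higher from compound 2 to compound 3 (within the scatter). Compound 3 is estimated at 14%, with a range from 2% to 30%.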

Compound 3, a percentage reported as inhibition, at one concentration (the size of the read-out at that concentration, not a potency): 69.5%
Compound 3: the middle estimate sits 55.5 percentage points below what was measured; the whole stated range lies below it.
By their numbers in this assay, from the lowest: compound 2; then compound 1; then compound 3.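

In this assay, the acyl or sulfonyl group on the amine nitrogen carries a large effect on the read-out: (furan-2-yl)carbonyl in place of (4-nitrophenyl)sulfonyl gives a number 62.1 percentage points higher from compound 2 to compound 3 (beyond the scatter) in this series. Substitution on the oxygen on an aromatic ring can therefore raise the number as well as lower it, since 3-(((furan-2-yl)carbonyl)amino)propyl in place of hydrogen gives a number 40.8 percentage points higher from compound 1 to compound 3 (beyond the scatter), whereas compound 2 stands below compound 1. No measurement on hand accounts for the size of either step. Still open, from the compounds shown here alone, is whether the furan ring or the carbonyl link matters more, which a benzoyl group or a (furan-2-yl)sulfonyl group on the same nitrogen would separate. A longer chain to that nitrogen also remains untested in the compounds shown.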